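Methyl for Fluoro: Following Compound 1 to Compound 4

This account rests on a few compounds, and the source may have more. Where it says the series, first, only, none or still open, it means among the compounds named here.

Of the compounds shown here, three sharing one core have been measured in an assay on HEK293 cells for inhibition of Voltage-dependent T-type calcium channel subunit alpha-1G (Homo sapiens), read by fluorescence, tested at 10 uM; on this read-out higher numbers stand for more inhibition at the one concentration tested (going by the name of the read-out) and lower numbers for less inhibition. Compound 1 `CCCc1nc(-c2ccccc2)c(CNCCN2CCN(c3ccccc3F)CC2)o1` gives 46.5% in this assay. Compound 2 `CCCc1nc(-c2ccccc2)c(CNCCCN2CCN(c3ccccc3Cl)CC2)o1` gives 64.7%, and compound 3 `CCCc1nc(-c2ccccc2)c(CNCCCN2CCN(c3cccc(Cl)c3)CC2)o1` gives 65.9%. Compound 1 therefore stands lowest of the three: its nearest neighbour, compound 2, lies beyond the scatter above it, and compound 3 lies further still. For the measured compounds named here, compounds 2 and 3 differ from compound 1 in more than one place, so their values show only that two related compounds sit higher. Going by the values given here, the one single-place step recorded, a number 1.2 percentage points higher from compound 2 to compound 3 (within the scatter), is within the scatter.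

Compound 4 `CCCc1nc(-c2ccccc2)c(CNCCN2CCN(c3ccccc3C)CC2)o1` differs from compound 1 in one place: methyl in place of fluoro on an aromatic carbon. Among the compounds with values here, no measured step exchanges fluoro for methyl, and the only step available moves a chlorine to another carbon of its ring without a change beyond the scatter. Nothing in the three measured compounds therefore points in either direction. The account expects in this assay a step of a number 3.5 percentage points higher from compound 1 to compound 4 (within the scatter) that stays within the scatter, with no clear direction. Compound 4 is estimated to give 50% in this assay, with a range from 30% to 70%.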

Compound 4, a percentage reported as inhibition, at one concentration (the size of the read-out at that concentration, not a potency): 51.3%
The estimate for compound 4 lay 1.3 percentage points below the measured number; low and high end bracket the measured number.
By their numbers in this assay, from the lowest: compounds 1 and 4 (each within the scatter of the next); then compounds 2 and 3 (each within the scatter of the next).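

In this assay, exchanging one heavy atom for another on the aromatic ring gives a number 4.8 percentage points higher from compound 1 to compound 4 (within the scatter), so this read-out does not separate the 2-methylphenyl group from the 2-fluorophenyl group on the core of compound 1. The earlier single-place step only moved a chlorine to another carbon of its ring, whereas this one replaces the group itself at a place ortho to a large group, and again the change stays within the scatter. No measured evidence bears on why the two groups read alike.

Going by these compounds, it remains open whether a methoxy group, a chlorine or a trifluoromethyl group at this same place would also stay within the scatter of compound 1 and compound 4. It is also open what a longer chain would do with the 2-methylphenyl group kept, since no pair shown differs in the chain alone and the higher numbers of compound 2 and compound 3 cannot be assigned to any one of their differences.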